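This account rests on a few compounds, and the source may have more. Where it says the series, first, only, none or still open, it means among the compounds named here.

Compound 1, `CNC(=S)N1CC(C)C(c2ccc(OC)cc2)=N1`, was examined in an in vitro assay on cells for inhibition of Amine oxidase [flavin-containing] A (Homo sapiens), read by Amplex Red, with a stated time of 15 min, tested at 100 uM (on this read-out lower numbers stand for less inhibition and higher numbers for more inhibition at the one concentration tested (going by the name of the read-out)), where compound 1 gives "not active" (no number reported), so compound 1 stands without a number on this read-out. Compound 2, `COc1ccc(C2=NN(C(N)=S)CC2C)cc1`, belongs to the same study and in this assay compound 2 gives 40%. Among the compounds with values here, no step is available between these two, so nothing more than their two results can be said of them. The account then turns to compound 3, `CNC(=S)N1CC(C)C(c2ccc(Cl)cc2)=N1`, which has not yet been measured in this assay. Compound 3 differs from compound 1 by chloro in place of methoxy on an aromatic carbon. Within the data shown here, with no measured step from compound 1 to any partner in this assay, the size and direction of the change cannot be read from the data; a step no larger than the scatter, or a small one in either direction, seems the most that can be expected. Compound 3 is therefore estimated to give 15% in this assay, within a range from 0% to 45%.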

Compound 3, a percentage reported as inhibition, at one concentration (the size of the read-out at that concentration, not a potency): "not active" (no number reported)
Compound 3: no number reported, and the estimate cannot be compared.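

In this assay, within the data shown here, compound 1 gives "not active" (no number reported) and compound 3 gives "not active" (no number reported), so no step between them can be read. The compounds shown leave open whether chloro in place of methoxy alters inhibition at all. Nothing available bears on these results.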